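The source may hold more compounds than are shown below. What is called first, only, known or untested is meant among the compounds shown, and "the series" means these compounds.

Measured compounds:
compound 1 `C/C(CN)=C(/F)CN(C[C@H]1Cc2ccccc2CN1)[C@H]1CCCc2cccnc21` — 61%
compound 2 `N[C@H]1CC[C@H](CN(C[C@H]2Cc3ccccc3CN2)[C@H]2CCCc3cccnc32)CC1` — 44%
compound 3 `N[C@H]1CC[C@H](N(C[C@H]2Cc3ccccc3CN2)[C@H]2CCCc3cccnc32)CC1` — 77%

In an ADME assay on microsomes from liver (Mus musculus) for metabolic stability (on this read-out lower numbers stand for a less stable compound and higher numbers for a more stable compound), compound 3 stands highest of the three numbers. Its nearest neighbour is compound 1, reached by a number 16 percentage points higher from compound 1 to compound 3 (beyond the scatter); its furthest is compound 2, reached by a number 33 percentage points higher from compound 2 to compound 3 (beyond the scatter).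

Compound 4 `C/C(CN(C[C@H]1Cc2ccccc2CN1)[C@H]1CCCc2cccnc21)=C(/F)CN` has not yet been measured in this assay. It differs from compound 3 as follows: 4-amino-3-fluoro-2-methylbut-2-en-1-yl in place of 4-aminocyclohexyl on an amine nitrogen.

The step that bears most directly on this change is a number 16 percentage points higher from compound 1 to compound 3 (beyond the scatter), where a 4-aminocyclohexyl took the place of a chain carrying a fluorine and a double bond on the same amine nitrogen, and the number rose modestly. The change from compound 3 to compound 4 runs the other way, putting a chain of that kind back in place of the ring, so a modest fall beyond the scatter is expected. The step of a number 33 percentage points higher from compound 2 to compound 3 (beyond the scatter) concerns a different change and gives no further guide.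

Compound 4 is therefore expected to give about 60% in this assay, within 45% to 75%, which corresponds to an expected a number 17 percentage points lower from compound 3 to compound 4 (beyond the scatter).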

Compound 4, percent of the compound remaining: 15%
Compound 4: middle estimate off by 45 percentage points, on the high side; the whole stated range lies above it.
By their numbers in this assay, from the lowest: compound 4; then compound 2; then compound 1; then compound 3.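

Compound 4 shows that, at this position on the amine nitrogen, the two fluorinated alkenyl chains are not interchangeable in this assay: rearranging the chain to 4-amino-3-fluoro-2-methylbut-2-en-1-yl gives a number 46 percentage points lower from compound 1 to compound 4 (beyond the scatter) and is enough to separate them. The replacement of the ring gives a number 62 percentage points lower from compound 3 to compound 4 (beyond the scatter) and the comparison with the ring-bearing chain gives a number 29 percentage points lower from compound 2 to compound 4 (beyond the scatter), so this chain ends up below both cyclohexyl-containing compounds. Nothing available explains the drop.

The compounds shown leave open whether the fall follows the fluorine, the methyl or the double bond in this chain. A saturated 4-aminobutyl chain, or the same alkenyl chain with hydrogen in place of fluorine, would help separate these features.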